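Benzofuran bis-amidines: methoxy step in cytotoxicity

A few compounds are considered here, and "the series" means these few. Any claim that something is new, unique, unknown or untested is made for them only; others in the source may bear on it.

Compound 1 `CC(C)NC(=N)c1ccc(-c2cc3ccc(C(=N)NC(C)C)cc3o2)cc1` and compound 3 `COc1cc(C(=N)NC(C)C)ccc1-c1cc2ccc(C(=N)NC(C)C)cc2o1` share one core and differ by methoxy in place of hydrogen on an aromatic carbon. In an ADME assay on L6 cells (Rattus norvegicus) for cytotoxicity (a higher number here means a weaker inhibitor, a lower number a stronger inhibitor), compound 1 gives only a limit, > 199000 nM. Compound 3 likewise gives only a limit, > 181000 nM. The step that the two limits leave unreadable from compound 1 to compound 3 cannot be read because the limit of > 199000 nM in this assay, at which 1 of the 3 values shown sits, and the limit of > 181000 nM in this assay, at which 1 of the 3 values shown sits, cap both values. Compound 2 `N=C(N)c1cccc(-c2cc3ccc(C(=N)N)cc3o2)c1` carries a different core; the difference between the two cores is not broken down here. In this assay, within the data shown here, compound 2 is the only compound with a number, 131000 nM. Compound 4 `COc1ccc(C(=N)N)cc1-c1cc2ccc(C(=N)N)cc2o1` is not yet measured and differs from compound 2 by methoxy in place of hydrogen on an aromatic carbon. This is the same kind of change as from compound 1 to compound 3 but not the same: in compound 3 the methoxy stands meta to a group of 6 heavy atoms, in compound 4 para to a group of 3 heavy atoms. No readable step for this change exists among the measured compounds, so the expectation rests on compound 2 and its value 131000 nM alone. The expected step is small, a 1.1-fold higher number from compound 2 to compound 4 (0.06 log units; within the scatter), and it is estimated with the upper end reaching the region where only limits were reported. Compound 4 is therefore estimated at 150000 nM, expected between 70000 nM and 320000 nM.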

Compound 4, half-maximal inhibitory concentration: 128000 nM
The estimate for compound 4 lay 1.2-fold (0.07 log units) above the measured number; the range from low to high includes it.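

In this assay methoxy in place of hydrogen on an aromatic carbon gives a 1.0-fold lower number from compound 2 to compound 4 (0.01 log units; within the scatter) on the core of compound 2, with the methoxy ortho to a large group and para to a group of 3 heavy atoms; this one readable step shows no change of the number on this core at this place, and it does not show that the change behaves alike on another core. The matching step on the core of compound 1 cannot be read, so the two cores cannot be compared for this change, and compound 3 stands only at a limit: the limit of > 181000 nM in this assay, at which 1 of the 4 values shown sits. Compound 1 likewise stands only at a limit: the limit of > 199000 nM in this assay, at which 1 of the 4 values shown sits.

Still open, on these data alone, is whether a hydroxyl group, an amine or a carboxylic acid in place of the same hydrogen, or a chain longer than methoxy such as ethoxy, would leave the number in this assay as flat as methoxy does on the core of compound 2. Also open, as far as these compounds go, is what methoxy does at other aromatic carbons of that core, and how large the step is on the core of compound 1.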